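A few compounds are considered here, and "the series" means these few. Any claim that something is new, unique, unknown or untested is made for them only; others in the source may bear on it.

For the measured compounds named here, compound 1 `O=C1CCC(N2C(=O)c3cccc(Nc4ccccn4)c3C2=O)C(=O)N1` has the lower number of the two measured members in an assay on FRT-Jurkat cells for inhibition of nuclear factor NF-kappa-B complex (Homo sapiens), read by flow cytometry, with a stated time of 24 h, tested at 10 uM; a lower number here means less inhibition, a higher number more inhibition at the concentration tested (going by the name of the read-out): compound 1 gives 1%, the lowest of the two numbers in hand. The other measured member, compound 2 `CC(C)(C)c1ccc(Nc2ccc3c(c2)C(=O)N(C2CCC(=O)NC2=O)C3=O)cc1`, gives 17%, a number beyond the scatter above that of compound 1. Going by the values given here, no pair of measured compounds differs in one place only, so no single-change step has been seen directly in this set.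

Compound 3 `CCc1ccc(Nc2cccc3c2C(=O)N(C2CCC(=O)NC2=O)C3=O)cc1` differs from compound 1 in a single place: 4-ethylphenyl in place of pyridin-2-yl on a nitrogen on an aromatic ring. Among the compounds with values here, the amine on the shared core is retained, and the only change is the group carried on that nitrogen. Nothing measured shows what this exchange does, and the value of compound 2 cannot be read as a step to compound 3 since no single difference links them. A modest rise from the floor is expected for a number 7 percentage points higher from compound 1 to compound 3 (within the scatter), though a step within the scatter would not be surprising. Compound 3 is estimated at 8%, with a range from -5% to 25%.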

Compound 3, a percentage reported as inhibition, at one concentration (the size of the read-out at that concentration, not a potency): 17%
Compound 3: the middle estimate sits 9 percentage points below what was measured; measured number inside the range.
By their numbers in this assay, from the lowest: compound 1; then compounds 2 and 3 (each within the scatter of the next).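

In this assay there is a number 16 percentage points higher from compound 1 to compound 3 (beyond the scatter) when 4-ethylphenyl replaces pyridin-2-yl on a nitrogen on an aromatic ring. This first single-change step in the series shows that the group carried on that nitrogen can shift the read-out beyond the scatter while the shared core and the amine link stay fixed. The exchange alters two things together, replacing a ring with a hetero atom by a ring of carbon only and adding the ethyl group, and no measurement in hand bears on why the number moves.

The step cannot separate these two parts: plain phenyl on the same nitrogen would show what the ring exchange does without the ethyl group, and an ethyl-bearing pyridinyl would show the reverse. Going by these compounds, how far the read-out depends on the group at the 4-position of the phenyl ring also remains open, and a longer chain, a methoxy group or a carboxylic acid there would begin to test this.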